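This account rests on a few compounds, and the source may have more. Where it says the series, first, only, none or still open, it means among the compounds named here.

The measured compounds:
Compound 1, `CCc1nc2c(-c3ccc(Cl)cc3Cl)ccnc2n1C(CCOC)C1CC1`: in an assay for binding affinity to Corticotropin releasing factor receptor (Rattus norvegicus) (a lower number here means a stronger inhibitor, a higher number a weaker inhibitor), compound 1 gives 1.5 nM.
Compound 2, `CCc1nc2c(-c3ccc(Cl)cc3Cl)ccnc2n1[C@@H](CC)C1CC1`: in this assay compound 2 gives 0.4 nM.

Of these two numbers compound 2 stands lowest, which here means the stronger binder; its nearest neighbour is compound 1, and the step of a 3.8-fold lower number from compound 1 to compound 2 (0.57 log units; beyond the scatter) lies beyond the scatter. The unmeasured compound 3, `CCc1nc2c(-c3ccc(Cl)cc3Cl)ccnc2n1C(C)C1CCC1`, differs from compound 2 in one place: 1-cyclobutylethyl in place of 1-cyclopropylpropyl on an aromatic nitrogen. The two groups consist of the same atoms joined differently, so this is a rearrangement rather than a gain or loss of atoms. Among the compounds with values here, the only measured step, a 3.8-fold lower number from compound 1 to compound 2 (0.57 log units; beyond the scatter), concerns a different kind of change, 1-cyclopropylpropyl in place of 1-cyclopropyl-3-methoxypropyl, so it offers little direct guidance; it does show that this part of the molecule matters in this assay. Within the data shown here, no measured example of a change in ring size exists here. The expected step is therefore small, close to the scatter, leaning if anything towards a higher number: a 1.8-fold higher number from compound 2 to compound 3 (0.24 log units; within the scatter) is the estimated change. Compound 3 is accordingly expected to give about 0.7 nM in this assay, within a likely range from 0.25 nM to 2 nM.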

Compound 3, inhibition constant: 1 nM
Compound 3: middle estimate off by 1.4-fold (0.15 log units), on the low side, within the range that was stated.
By their numbers in this assay, from the lowest: compound 2; then compounds 3 and 1 (each within the scatter of the next).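

Within this position on the aromatic nitrogen, rearranging the same carbon atoms from 1-cyclopropylpropyl into 1-cyclobutylethyl gives a 2.5-fold higher number from compound 2 to compound 3 (0.40 log units; beyond the scatter) in this assay, so a change with no gain or loss of atoms still registers here. The other new step, a 1.5-fold lower number from compound 1 to compound 3 (0.18 log units; within the scatter), shows that 1-cyclobutylethyl and 1-cyclopropyl-3-methoxypropyl cannot be told apart in this measurement, even though only the second carries a methoxy group. Compound 2 therefore remains the strongest binder of the three, with its steps to both other compounds beyond the scatter, although those steps are only modest.

No supporting measurement here explains these differences. Open questions are how much of the step to compound 3 belongs to the ring size, how much to the shorter ethyl chain and how much to the defined stereocentre present only in 1-cyclopropylpropyl, and whether a cyclopentyl ring or an amine on the side chain would be tolerated at this position.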